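The compounds below may be only part of what the source reports. "The series", "measured", "known", "first", "only" and "open" are said of these compounds alone.

In an ADME assay on microsomes from liver (Rattus norvegicus) for metabolic stability, read by LC-MS, using NADPH, with a stated time of 30 min, tested at 0.1 uM, in the presence of a further agent that is not named here (a lower number here means that less of the compound is left, a higher number that more of the compound is left), compound 3 `Nc1ncc(-c2ccc(C(=O)N3CC[C@H](O)C3)cc2)nc1-c1ccc(C(F)(F)F)cc1` gives > 90% as a limit of the assay, not a number. Compound 1 `Nc1ncc(-c2ccc(C(=O)N3CC(O)C3)cc2)nc1-c1ccc(C(F)(F)F)cc1` gives > 90% as a limit too. Compound 2 `NC(=O)c1ccc(-c2cnc(N)c(-c3ccc(C(F)(F)F)cc3)n2)cc1` gives > 90% as a limit as well.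

Compound 4 `Nc1ncc(-c2ccc(C(=O)N3CCC(O)CC3)cc2)nc1-c1ccc(C(F)(F)F)cc1` differs from compound 3 in one place, with 4-hydroxypiperidin-1-yl in place of 3-hydroxypyrrolidin-1-yl on a carbonyl carbon. Three measured steps changed the group on that same carbonyl carbon, namely a step that the two limits leave unreadable from compound 1 to compound 2 and a step that the two limits leave unreadable from compound 1 to compound 3 and also a step that the two limits leave unreadable from compound 2 to compound 3 and so none of them offers a size to carry over.

Given the limit of > 90% in this assay, at which 3 of the 3 values shown sit, for compound 1, compound 2 and compound 3, no change beyond the usual scatter is expected in this assay for this swap, and the direction stays open. The expected step is a step that the limit leaves unreadable from compound 3 to compound 4 and its size is only an estimate. The assay may well report a limit again. For compound 4 the estimated value is 93% with an expected range from 82% to 100% in this read-out.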

Compound 4, percent of the compound remaining: > 90%
Compound 4 was reported as a limit; the forecaster's own chance of this, stated with the estimate: 70%; the middle value lies beyond the limit too.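

Compound 4 is also reported as a limit rather than a number, and no step between it and compound 1, compound 2 or compound 3 can be read because all four share one limit: the limit of > 90% in this assay, at which 4 of the 4 values shown sit.

The compounds shown leave open whether these four groups on the carbonyl carbon differ at all in this assay.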